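Aryl Replacement on Compound 1: Working Notes

This account rests on a few compounds, and the source may have more. Where it says the series, first, only, none or still open, it means among the compounds named here.

The series is followed in an assay on membranes from liver for displacement of a labelled ligand from Glucagon receptor (Mus musculus), read by scintillation counting, with a stated time of 60 min; a higher number here means a weaker inhibitor, a lower number a stronger inhibitor. Compound 1, `C[C@H](c1ccc(C(=O)NCCC(=O)O)cc1)N1C(=O)C(c2ccc(F)cc2)=N[C@]12CC[C@@H](C(C)(C)C)CC2`, gives 2500 nM in this assay, the highest of the two numbers recorded so far. Going by the values given here, compound 2, `CC(C)CC[C@H](c1ccc(C(=O)NCc2nn[nH]n2)cc1)N1C(=O)C(c2cc(Cl)cc(Cl)c2)=N[C@]12CC[C@@H](C(C)(C)C)CC2`, gives 280 nM in this assay; it differs from compound 1 in several places at once, so the two values show only that compound 2 sits at the lower number and no single step can be read from the pair.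

Compound 3, `C[C@H](c1ccc(C(=O)NCCC(=O)O)cc1)N1C(=O)C(c2cccc(OC(F)(F)F)c2)=N[C@]12CC[C@@H](C(C)(C)C)CC2`, has not yet been measured. It differs from compound 1 in one place: 3-(trifluoromethoxy)phenyl in place of 4-fluorophenyl on a carbon with a double bond to nitrogen. Among the compounds with values here, no measured pair in the set isolates this change, so there is no direct precedent for its size.

With only the two measured values to go on, a modest step toward a lower number is expected for compound 3, though one that may not clearly exceed the usual scatter; this expectation is expressed as a 2.1-fold lower number from compound 1 to compound 3 (0.32 log units; beyond the scatter). The estimate for compound 3 in this assay is 1200 nM, with a range from 400 nM to 4000 nM.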

Compound 3, half-maximal inhibitory concentration: 1500 nM
Compound 3: middle estimate off by 1.3-fold (0.10 log units), on the low side; the measured number falls inside the stated range.
By their numbers in this assay, from the lowest: compound 2; then compounds 3 and 1 (each within the scatter of the next).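

In this assay, 3-(trifluoromethoxy)phenyl in place of 4-fluorophenyl on a carbon with a double bond to nitrogen gives a 1.7-fold lower number from compound 1 to compound 3 (0.22 log units; within the scatter), so compound 3 and compound 1 cannot be told apart at this position. The entering group has 11 heavy atoms against 7 and carries 1 hydrogen-bond acceptor where the leaving group has 0, and this exchange still leaves the read-out within the scatter. Going by these compounds alone, this is the first comparison that isolates one place, which the pair of compound 1 and compound 2, differing in several places at once, could not do; no measurement at hand explains this result.

From the compounds shown here alone, the change alters both the group on the phenyl ring and the number in its name, so 3-fluorophenyl and 4-(trifluoromethoxy)phenyl would be needed to separate the two, and whether either gives a step beyond the scatter remains open. Also open, going by these compounds, is how this place responds to a group of another kind, such as a phenyl ring bearing a dimethylamino group or a carboxylic acid, or a saturated cyclohexyl ring.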